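This account rests on a few compounds, and the source may have more. Where it says the series, first, only, none or still open, it means among the compounds named here.

Three compounds sharing a common core were tested in a toxicity assay on THP-1 cells (Homo sapiens) for inhibition; on this read-out lower numbers stand for higher toxicity in this test and higher numbers for lower toxicity in this test. Compound 1 `Cn1c(-c2cccc(Cl)c2)cnc1NC(=O)c1ccc(F)cc1` reaches only the assay limit of > 50000 nM in this assay. Compound 2 `COc1ccc(-c2cnc(NC(=O)c3cccnc3)n2C)cc1` likewise returns only a limit, > 100000 nM. Compound 3 `COc1ccc2c(c1)nc(NC(=O)c1ccc(F)cc1)n2C` also stops at a limit, with > 100000 nM. Among the measured compounds shown here, compound 2 thus stands at the limit of > 100000 nM in this assay, at which 2 of the 3 values shown sit, while compound 1 sits at the limit of > 50000 nM in this assay, at which 1 of the 3 values shown sits; none of the three gave a number, and no step between measured compounds can be read from them. Compound 4 `COc1ccc(-c2cnc(NC(=O)c3cnco3)n2C)cc1` has not yet been measured in this assay. It differs from compound 2 by 1,3-oxazol-5-yl in place of pyridin-3-yl on a carbonyl carbon. With every measured value resting at a limit, no movement beyond the scatter is expected from this change. The step of a number no higher from compound 2 to compound 4 (the limit leaves the size open) is expected to be none beyond the scatter. Compound 4 is expected to give 100000 nM in this assay, within a range from 40000 nM to 250000 nM, most probably reported again only as a limit.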

Compound 4, half-maximal cytotoxic concentration: > 100000 nM
Compound 4: only a limit was reported; the forecaster's own chance of this, stated with the estimate: 80%; the middle value sits exactly at the limit.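

Among the compounds shown here, compound 2 and compound 4 both stop at a limit in this assay, and no step between them can be read. The compounds shown leave open where any of them would give an actual half-maximal cytotoxic concentration, and whether 1,3-oxazol-5-yl in place of pyridin-3-yl on a carbonyl carbon shifts it at all.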